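Cyclohexyl in place of 2-methylphenyl: what half-life to expect

The source may hold more compounds than are shown below. What is called first, only, known or untested is meant among the compounds shown, and "the series" means these compounds.

In a physicochemical assay for pharmacokinetics (a lower number here means that the compound disappears faster, a higher number that the compound lasts longer), compound 1 `O=C(NCc1ccccc1Br)N1C(=O)c2ccccc2S1(=O)=O` stands at 0.253 h and compound 2 `COc1ccc(CNC(=O)N2C(=O)c3ccccc3S2(=O)=O)cc1` at 0.187 h while compound 3 `Cc1ccccc1CNC(=O)N1C(=O)c2ccccc2S1(=O)=O` reaches 0.792 h as the highest of the three numbers. Compound 3 stands clear of compound 1, with a 3.1-fold higher number from compound 1 to compound 3 (0.50 log units; beyond the scatter) as the step between them.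

Compound 4 `O=C(NCC1CCCCC1)N1C(=O)c2ccccc2S1(=O)=O` has cyclohexyl in place of 2-methylphenyl on a saturated chain carbon bound to an amide-type nitrogen, and the count for this change reads cyclohexyl in place of 2-methylphenyl on a saturated chain carbon bound to an amide-type nitrogen in full. Two measured steps act at that same place. One is a 1.4-fold lower number from compound 1 to compound 2 (0.13 log units; within the scatter) and the other is a 4.2-fold higher number from compound 2 to compound 3 (0.63 log units; beyond the scatter) as the largest step seen so far. Neither of them replaces an aromatic ring with a non-aromatic one, so they give only a rough size for changes at this place and no sure direction. Compound 3 already holds the top number of the three, so a small fall looks more likely than a further rise. The estimated change is a 1.8-fold lower number from compound 3 to compound 4 (0.25 log units; within the scatter) and so no firm step beyond the scatter is expected. For compound 4 the expected half-life is 0.45 h with an estimated range from 0.17 h to 1.2 h in this measurement.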

Compound 4, half-life: 0.963 h
The estimate for compound 4 lay 2.1-fold (0.33 log units) below the measured number, within the range that was stated.
By their numbers in this assay, from the lowest: compounds 2 and 1 (each within the scatter of the next); then compounds 3 and 4 (each within the scatter of the next).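

In this assay, going by these compounds alone, the first swap of an aromatic ring for a non-aromatic one at this place, on a saturated chain carbon bound to an amide-type nitrogen, gives a 1.2-fold higher number from compound 3 to compound 4 (0.08 log units; within the scatter), so compound 3 and compound 4 cannot be told apart and the aromatic ring of compound 3 proves not to be required for a number of this size. Cyclohexyl also stands clear of the other two groups, with a 5.1-fold higher number from compound 2 to compound 4 (0.71 log units; beyond the scatter) and a 3.8-fold higher number from compound 1 to compound 4 (0.58 log units; beyond the scatter), so the compounds fall into two pairs, 2-methylphenyl and cyclohexyl in the upper one and 4-methoxyphenyl and 2-bromophenyl in the lower one, and having an aromatic ring at this place does not by itself fix the number. Nothing among the data shown explains why these groups divide in this way.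

The compounds shown leave open whether this holds for other non-aromatic groups at the same place, such as cyclopentyl, a longer open chain or a piperidine ring. They also leave open what a carboxylic acid or an amine on the cyclohexyl ring would do to the half-life.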